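Working notes on the amine substituent series at protein kinase C delta

The compounds below may be only part of what the source reports. "The series", "measured", "known", "first", "only" and "open" are said of these compounds alone.

Within the data shown here, compound 3 `N#Cc1cnc(NCc2cnccc2C(F)(F)F)cc1NC[C@H]1CC[C@H](O)CC1` holds the only value in this set that is a number: in an assay on isolated protein for inhibition of protein kinase C delta type (Homo sapiens), read by TR-FRET, with a stated time of 2 h (a higher number here means a weaker inhibitor, a lower number a stronger inhibitor), compound 3 gives 2000 nM. Compound 1 `N#Cc1cnc(NCc2cnccc2C(F)(F)F)cc1N[C@H]1C[C@H](O)C1` sits at a limit of the assay, giving > 10000 nM in this assay. Compound 2 `CO[C@H]1CC[C@H](Nc2cc(NCc3cnccc3C(F)(F)F)ncc2C#N)CC1` likewise sits at a limit, giving > 10000 nM in this assay. The steps toward compound 3 are therefore readable only as bounds, an at least 5.0-fold lower number from compound 1 to compound 3 (0.69 log units; beyond the scatter) and an at least 5.0-fold lower number from compound 2 to compound 3 (0.69 log units; beyond the scatter), both resting on (the limit of > 10000 nM in this assay, at which 2 of the 3 values shown sit). Compound 4 `N#Cc1cnc(NCc2cnccc2C(F)(F)F)cc1NCCC1CCOCC1` differs from compound 3 by (oxan-4-yl)methyl in place of 4-hydroxycyclohexyl on a saturated chain carbon bound to a nitrogen on an aromatic ring, on a saturated chain carbon bound to a nitrogen on an aromatic ring. Among the measured compounds shown here, no measured pair isolates this change. With two of three neighbours at the limit, a drift back toward it is expected, as a 3.0-fold higher number from compound 3 to compound 4 (0.48 log units; beyond the scatter). Compound 4 is expected near 6000 nM, within 2000 nM to 20000 nM.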

Compound 4, half-maximal inhibitory concentration: > 10000 nM
Compound 4: only a limit was reported (the forecaster's own chance of this, stated with the estimate: 40%); middle value at least 1.6-fold (0.22 log units) away from the limit.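

Compound 4 sits at a limit of this assay, giving > 10000 nM. The same atoms joined differently, with (oxan-4-yl)methyl carrying 0 hydrogen-bond donors where 4-hydroxycyclohexyl carries 1, give an at least 5.0-fold higher number from compound 3 to compound 4 (0.69 log units; beyond the scatter), so this position does not tolerate every group of this size. The steps from compound 1 and from compound 2 to compound 4 cannot be read, and the series still rests on a single number: the limit of > 10000 nM in this assay, at which 3 of the 4 values shown sit.

The compounds shown do not separate the loss of the hydroxyl from the change of ring and chain. Open, going by these compounds, is whether an amine or a carboxylic acid on the cyclohexyl ring would hold the value of compound 3.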